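Reversing two ring stereocentres in an iminosugar acid

The source may hold more compounds than are shown below. What is called first, only, known or untested is meant among the compounds shown, and "the series" means these compounds.

Two stereoisomers of the same iminosugar acid have been measured in an assay on isolated protein for inhibition of cytosolic endo-beta-N-acetylglucosaminidase (Homo sapiens), tested at 1000 uM; a lower number here means less inhibition, a higher number more inhibition at the concentration tested (going by the name of the read-out). Compound 1 `O=C(O)[C@H]1NC[C@H](O)[C@H](O)[C@@H]1O` gives 26% in this assay, while compound 2 `O=C(O)[C@@H]1NC[C@@H](O)[C@@H](O)[C@@H]1O` gives 2.1%, the lowest of the two numbers. The step of a number 23.9 percentage points lower from compound 1 to compound 2 (beyond the scatter) is traced to configuration alone, because of the fact that compounds 1 and 2 differ only in the configuration as drawn. Compound 3 `O=C(O)[C@@H]1NC[C@@H](O)[C@H](O)[C@H]1O` is not yet measured; it differs from compound 2 only as follows: the two compounds have the same atoms and bonds and differ only in configuration as drawn: 2 of 4 stereo elements differ; a stereocentre at a saturated ring carbon is drawn R in compound 2 and S in compound 3; a stereocentre at a saturated ring carbon is drawn R in compound 2 and S in compound 3. Within the data shown here, the one measured step that bears on this change concerns configuration at three centres and was a modest fall, so a change at two centres, bringing two of them back to the drawing of compound 1, is expected to move this assay upward by a modest amount at most. The step of a number 10.9 percentage points higher from compound 2 to compound 3 (beyond the scatter) is the estimate, and compound 3 is expected to give about 13%, with a range from 0% to 35%.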

Compound 3, a percentage reported as inhibition, at one concentration (the size of the read-out at that concentration, not a potency): 50%
Beside the measured number, compound 3's estimate is 37 percentage points below it, and the stated range ends below it.
By their numbers in this assay, from the lowest: compound 2; then compound 1; then compound 3.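

In this assay, configuration alone now moves the read-out upward as well as downward: the fact that compounds 2 and 3 differ only in the configuration as drawn. Changing just two ring stereocentres gives a number 47.9 percentage points higher from compound 2 to compound 3 (beyond the scatter), a large step where the earlier step across three stereocentres was modest, so fewer changed centres did not mean a smaller change in the read-out. The arrangement drawn in compound 1 is also not the highest of the three, with a number 24 percentage points higher from compound 1 to compound 3 (beyond the scatter), and this step again involves configuration only: the fact that compounds 1 and 3 differ only in the configuration as drawn.

Going by these compounds, it remains open which of the two centres changed from compound 2 to compound 3 carries the step, as both change together in this pair. Also open, on these data alone, is how the arrangement in compound 3 behaves when an amide or a methyl ester replaces the carboxylic acid.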